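A few compounds are considered here, and "the series" means these few. Any claim that something is new, unique, unknown or untested is made for them only; others in the source may bear on it.

Two compounds share one core and differ only in the group on a carbonyl carbon. Compound 1, `CC1=C(C(=O)OCC(C)C)C(c2cccs2)NC(=O)N1`, gives 11% in an assay on membranes from HeLa cells for displacement of a labelled ligand from adenosine receptor A3 (Homo sapiens), read by scintillation counting, with a stated time of 180 min, tested at 1 uM; on this read-out lower numbers stand for less inhibition and higher numbers for more inhibition at the one concentration tested (going by the name of the read-out). Compound 2, `CCCC(=O)C1=C(C)NC(=O)NC1c1cccs1`, gives 2% in this assay; this is the lower of the two numbers, compound 1 is its nearest neighbour, and the step of a number 9 percentage points lower from compound 1 to compound 2 (within the scatter) lies within the scatter. Compound 3, `CC1=C(C(=O)CC(C)C)C(c2cccs2)NC(=O)N1`, has not been measured yet. It differs from compound 2 by methyl in place of hydrogen on a saturated chain carbon bound to two saturated chain carbons. Among the measured compounds shown here, the only measured step, a number 9 percentage points lower from compound 1 to compound 2 (within the scatter), concerns a different exchange on the carbonyl carbon and was itself within the scatter; no measured step here speaks directly to a methyl in place of hydrogen on a saturated chain carbon. The step from compound 2 to compound 3 is therefore expected to stay within the scatter, a number 2 percentage points higher from compound 2 to compound 3 (within the scatter). Compound 3 is estimated at 4%, with a range from -6% to 15%.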

Compound 3, a percentage reported as inhibition, at one concentration (the size of the read-out at that concentration, not a potency): 18%
Compound 3: the middle estimate sits 14 percentage points below what was measured; measured number above the stated range.
By their numbers in this assay, from the lowest: compounds 2, 1 and 3 (each within the scatter of the next, the first and the last beyond it).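

In this assay, among the compounds shown here, a single added methyl on a saturated chain carbon bound to two saturated chain carbons, the change from propyl to isobutyl, gives a number 16 percentage points higher from compound 2 to compound 3 (beyond the scatter) and is the first step here to clear the scatter, so this place on the chain can shift the read-out, if only modestly. With the branch kept, isobutyl in place of isobutoxy on the carbonyl carbon gives a number 7 percentage points higher from compound 1 to compound 3 (within the scatter) and so does not separate these two branched compounds. Nothing available explains why the added methyl shifts the number.

On these data alone, whether a longer chain such as pentyl or a ring such as cyclopropyl would shift the number further at this place stays open. So does whether propoxy would stand to isobutoxy as propyl stands to isobutyl.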